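Swapping propyl for 4-fluorophenyl on a sulfonyl sulfur

A few compounds are considered here, and "the series" means these few. Any claim that something is new, unique, unknown or untested is made for them only; others in the source may bear on it.

In a functional assay on Huh-7 cells (Homo sapiens) for cytotoxicity, read by MTT assay, with a stated time of 72 h (on this read-out higher numbers stand for lower toxicity in this test and lower numbers for higher toxicity in this test), compound 1 (`CCCS(=O)(=O)N1CCC2(CC1)OOC1(CCCC1)OO2`) gives > 100 ug/mL as its result, which is a limit of the assay and not a number. Compound 2 (`CCCCS(=O)(=O)N1CCC2(CC1)OOC1(CCCCC1)OO2`) gives > 100 ug/mL as its result, again a limit. Compound 3 (`Cc1ccc(S(=O)(=O)N2CCC3(CC2)OOC2(CCCCC2)OO3)cc1`) gives > 100 ug/mL as its result, again a limit. The whole picture so far is the limit of > 100 ug/mL in this assay, at which 3 of the 3 values shown sit, and no exact number has been measured.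

Compound 4 (`O=S(=O)(c1ccc(F)cc1)N1CCC2(CC1)OOC1(CCCC1)OO2`) differs from compound 1 in one place: 4-fluorophenyl in place of propyl on a sulfonyl sulfur and so 4-fluorophenyl stands in place of propyl on a sulfonyl sulfur. The closest measured change is a step that the two limits leave unreadable from compound 2 to compound 3 and there too an aromatic ring replaces a chain, so it offers a parallel without a size. With no readable step to go on, no step beyond the scatter is expected in this assay and no direction can be given. The estimated change is a step that the limit leaves unreadable from compound 1 to compound 4 and it may stay hidden behind the limit. For compound 4 the expected value is 150 ug/mL with an estimated range from 70 ug/mL to 300 ug/mL and a limit is the likeliest report.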

Compound 4, half-maximal cytotoxic concentration: > 100 ug/mL
Compound 4 ended at the assay's limit; the forecaster's own chance of this, stated with the estimate: 85%; the middle value lies beyond the limit too.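

No step can be read from compound 1 to compound 4, since both results are limits of the assay and not numbers: the limit of > 100 ug/mL in this assay, at which 4 of the 4 values shown sit.

The compounds shown leave open how far apart their true values lie, and whether any group on the sulfonyl sulfur would give an exact number in this test.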